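A few compounds are considered here, and "the series" means these few. Any claim that something is new, unique, unknown or untested is made for them only; others in the source may bear on it.

Working notes on the series.

Compound 1, `CCCCOC(=O)NS(=O)(=O)c1sc(CC(C)C)cc1-c1ccc(CN2C(=O)CN(C)C2=O)cc1`, is the reference point here. In an assay on membranes from uterus for displacement of a labelled ligand from Angiotensin type II receptor (Sus scrofa), with a stated time of 1.5 h (on this read-out higher numbers stand for weaker inhibition and lower numbers for stronger inhibition), compound 1 gives 68.6 nM. Among the measured compounds shown here, its one measured companion is compound 2, `CCCCOC(=O)NS(=O)(=O)c1sc(CC(C)C)cc1-c1ccc(CN2C(=O)N(C)C(C)(C)C2=O)cc1`, which in this assay gives 3.6 nM. For the measured compounds named here, compound 1 therefore stands at the highest of the two numbers known so far, with compound 2 sitting a 19-fold lower number from compound 1 to compound 2 (1.28 log units; beyond the scatter).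

Compound 3, `CCCCOC(=O)NS(=O)(=O)c1sc(CC(C)C)cc1-c1ccc(CN2C(=O)CCC2=O)cc1`, has not yet been measured in this assay. It differs from compound 1 by 2,5-dioxopyrrolidin-1-yl in place of 3-methyl-2,5-dioxoimidazolidin-1-yl on a saturated chain carbon bound to an aromatic carbon. Going by the values given here, the only step with data, from compound 1 to compound 2, changed the same ring on the same saturated chain carbon and was large, but it added methyl groups to that ring while the present change removes one ring nitrogen and its methyl. That step cannot be read directly onto compound 3, so the expected movement is uncertain in direction and probably small. For compound 3 the estimate is 80 nM, a step of a 1.2-fold higher number from compound 1 to compound 3 (0.07 log units; within the scatter), with the range 20 nM to 300 nM expected to cover the eventual number.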

Compound 3, inhibition constant: > 10000 nM
Compound 3: a limit, no number (the forecaster's own chance of this, stated with the estimate: 5%); at least 120-fold (2.09 log units) between middle value and limit.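

Compound 3 does not give a number in this assay, only a limit of the assay: the limit of > 10000 nM in this assay, at which 1 of the 3 values shown sits.

The ring on the saturated chain carbon bound to an aromatic carbon is therefore not freely exchangeable: 2,5-dioxopyrrolidin-1-yl in place of 3-methyl-2,5-dioxoimidazolidin-1-yl gives an at least 140-fold higher number from compound 1 to compound 3 (2.16 log units; beyond the scatter) and the same group in place of 3,4,4-trimethyl-2,5-dioxoimidazolidin-1-yl gives an at least 2700-fold higher number from compound 2 to compound 3 (3.44 log units; beyond the scatter) at this position. The earlier comparison showed only that added methyl groups on the ring can shift the number; this one shows that exchanging the ring itself, with its nitrogen and methyl group gone, takes the read-out to the limit among the three compounds shown.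

Open, on these data alone, is whether the change follows the ring nitrogen itself or the methyl group on it: the same ring with hydrogen or an ethyl group on that nitrogen would separate the two. Also open, as far as these compounds go, is whether 3,3-dimethyl-2,5-dioxopyrrolidin-1-yl at this position would return a measurable number.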